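Removing a Ring Methyl Under a Cytotoxicity Ceiling

The source may hold more compounds than are shown below. What is called first, only, known or untested is meant among the compounds shown, and "the series" means these compounds.

Compound 1 `CON=C1CCC(CN2CCN(c3nc(=O)c4cc(C(F)(F)F)cc([N+](=O)[O-])c4s3)CC2)CC1`: in an ADME assay on Vero cells (Chlorocebus sabaeus) for cytotoxicity (a lower number here means that less compound is tolerated, a higher number that more compound is tolerated), compound 1 gives > 64 ug/mL, which is a limit of the assay and not a number.
Compound 2 `CON=C1CCC(CN2CCN(c3nc(=O)c4cc(C(F)(F)F)cc([N+](=O)[O-])c4s3)C[C@H]2C)CC1`: in this assay compound 2 gives > 64 ug/mL, again only a limit.
Compound 3 `CON=C1CCC(CN2C(C)CN(c3nc(=O)c4cc(C(F)(F)F)cc([N+](=O)[O-])c4s3)CC2C)CC1`: in this assay compound 3 gives > 64 ug/mL, also a limit.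

Compound 3 therefore stands where every value shown stands: at the top of what the assay can report, with no actual number behind it, and the two further values shown are limits as well. The unmeasured compound 4 `CON=C1CCC(CN2CCN(c3nc(=O)c4cc(C(F)(F)F)cc([N+](=O)[O-])c4s3)CC2C)CC1` differs from compound 3 by hydrogen in place of methyl on a saturated ring carbon.

Among the measured compounds shown here, only one measured step involves a methyl on a saturated ring carbon, and it runs in the opposite direction: a step that the two limits leave unreadable from compound 1 to compound 2. Its size cannot be read, because the limit of > 64 ug/mL in this assay, at which 3 of the 3 values shown sit, puts both of its ends out of reach. So the measured steps give no sign of a change beyond the scatter from adding or removing such a methyl, and none is expected here either. The step expected from compound 3 to compound 4 is a number no higher from compound 3 to compound 4 (the limit leaves the size open). For compound 4 the estimate in this assay is 64 ug/mL, with a range from 32 ug/mL to 128 ug/mL, and most likely the assay will again report only its limit.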

Compound 4, half-maximal cytotoxic concentration: > 64 ug/mL
Compound 4 gave a limit, no number (the forecaster's own chance of this, stated with the estimate: 85%); the middle value sits exactly at the limit.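

Among the compounds shown here, no step from compound 4 to compound 1, compound 2 or compound 3 can be read, because both ends of each step sit at the same limit: the limit of > 64 ug/mL in this assay, at which 4 of the 4 values shown sit. The compounds shown leave open how much of any of them is tolerated in this assay and whether a methyl on a saturated ring carbon makes any difference there.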